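The source may hold more compounds than are shown below. What is called first, only, known or untested is meant among the compounds shown, and "the series" means these compounds.

The measured compounds:

Compound 1 `CCCCSc1nc(C(C)(C)C)ccc1CNC(=O)C(C)c1ccc(NS(C)(=O)=O)c(F)c1` in an assay on cells for antagonist activity at transient receptor potential cation channel subfamily V member 1 (Homo sapiens), read by FLIPR and calcium flux, with a stated time of 6 min (on this read-out lower numbers stand for stronger inhibition and higher numbers for weaker inhibition), gives 3.2 nM.
Compound 2 `CC(C(=O)NCc1ccc(C(C)(C)C)cc1N1CCCC1)c1ccc(NS(C)(=O)=O)c(F)c1` in this assay gives 8.1 nM.

Compound 2 stands at the higher of the two numbers. Its nearest neighbour is compound 1, whose number is lower by a gap that goes beyond the usual scatter of repeated runs, so on these two values compound 2 is the weaker of the pair. For the measured compounds named here, no step between them can be counted, since the two structures differ in more than one place.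

Compound 3 `CCCCOc1cc(C(C)(C)C)ccc1CNC(=O)C(C)c1ccc(NS(C)(=O)=O)c(F)c1` is not yet measured. It is reached from compound 2 by one change: butoxy in place of pyrrolidin-1-yl on an aromatic carbon. Going by the values given here, no pair differing only at this place has been measured, so the size of this step rests on the two values alone. Compound 1, with a four-carbon chain through sulfur on its core, gives 3.2 nM, and compound 3 carries a chain of the same length through oxygen; on that account the step is expected to lead toward a somewhat lower number but to stay within the usual scatter. The step itself is estimated to be a 1.6-fold lower number from compound 2 to compound 3 (0.21 log units; within the scatter). Compound 3 is estimated to give 5 nM in this assay, within a range from 1.5 nM to 15 nM.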

Compound 3, inhibition constant: 1.4 nM
For compound 3 the middle estimate is 3.6-fold (0.55 log units) above the measured one; the whole stated range lies above it.
By their numbers in this assay, from the lowest: compound 3; then compound 1; then compound 2.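

Read in this assay, this change gives a 5.8-fold lower number from compound 2 to compound 3 (0.76 log units; beyond the scatter), the first step that can be read at this aromatic carbon, ortho to a large group and meta to a tert-butyl group. Butoxy and pyrrolidin-1-yl match in heavy-atom count and in hydrogen-bond donors and acceptors, yet this pair lies beyond the usual scatter, so at this place those counts alone do not settle the read-out. The groups differ in that one is an open chain joined through oxygen and the other a five-membered non-aromatic ring joined through nitrogen, and nothing available explains why the open chain carries the lower number.

As far as these compounds go, whether a butylamino group, which keeps the nitrogen but opens the ring, would read like butoxy or like pyrrolidin-1-yl remains open, so the effects of the ring and of the linking atom cannot be told apart from this pair. From the compounds shown here alone, how a shorter chain such as methoxy, or a longer one such as hexyloxy, would read at this place also remains open.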